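Swapping a benzylamide for a morpholine amide

The source may report more compounds than this note shows. Statements on the series, on what has been measured and on what is new or still open speak of the compounds shown alone.

Measured compounds:
compound 1 `COc1cc2c(cc1OC)C(CC(=O)NC(C)(C)C)CC2`: 31.5%
compound 2 `COc1cc2c(cc1OC)C(CC(=O)NCc1ccccc1)CC2`: 30.6%

In a functional assay on the whole organism (strain Wistar) for inhibition, with Rattus norvegicus as the target, read by paw edema, with stated times of 60 min and 6 h, at a dose of 100 mg/kg by the oral route (on this read-out lower numbers stand for less inhibition and higher numbers for more inhibition at the one dose given (going by the name of the read-out)), compound 1 gives 31.5%, and compound 2 gives 30.6%. Compound 2 holds the lower of the two numbers, yet the gap is a number 0.9 percentage points lower from compound 1 to compound 2 (within the scatter), so the two compounds stand level within the scatter.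

Compound 3 `COc1cc2c(cc1OC)C(CC(=O)N1CCOCC1)CC2` is the next unmeasured member of this shared core. Its difference from compound 2 is morpholin-4-yl in place of benzylamino on a carbonyl carbon. Going by the values given here, the only measured step, a number 0.9 percentage points lower from compound 1 to compound 2 (within the scatter), also reworked the group on the amide-type nitrogen and left the read-out essentially unchanged. That step bears only loosely on the present one, since compound 3 also loses the amide hydrogen. Among the compounds with values here, with one flat step as the sole guide, a change of a number 2.6 percentage points lower from compound 2 to compound 3 (within the scatter) is expected, nothing beyond the scatter. Compound 3 is therefore estimated at 28%, within a range of 14% to 42%.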

Compound 3, a percentage reported as inhibition, in the whole organism at one dose (the size of the read-out at that dose, not a potency): 14.8%
Compound 3: the middle estimate sits 13.2 percentage points above what was measured, and the stated range covers the measured number.
By their numbers in this assay, from the lowest: compound 3; then compounds 2 and 1 (each within the scatter of the next).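

In this assay, morpholin-4-yl on the carbonyl carbon gives a number 15.8 percentage points lower from compound 2 to compound 3 (beyond the scatter), and set against the tert-butyl amide it gives a number 16.7 percentage points lower from compound 1 to compound 3 (beyond the scatter). This shows that the group at this position can affect the read-out: benzylamino and (tert-butyl)amino stood level, but morpholin-4-yl does not stand level with either. No measurement here explains the drop.

Morpholin-4-yl removes the amide hydrogen and brings in a ring oxygen in a single change, so the compounds shown cannot tell which of these, if either, goes with the lower number. Piperidin-1-yl, which has the ring but no oxygen, and methylamino, which keeps the amide hydrogen on a small group, would each test one side of that question.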